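Amide substituent variation on the shared core

The source may hold more compounds than are shown below. What is called first, only, known or untested is meant among the compounds shown, and "the series" means these compounds.

Measured so far:
compound 1, `Cc1ccc(CNC(=O)c2nn(-c3ccc(F)cc3)c(OC[C@@H](O)C[C@@H](O)CC(=O)O)c2C(C)C)cc1`: 15 nM
compound 2, `COc1ccccc1CNC(=O)c1nn(-c2ccc(F)cc2)c(OC[C@@H](O)C[C@@H](O)CC(=O)O)c1C(C)C`: 22 nM

In an assay on microsomes from liver for inhibition of 3-hydroxy-3-methylglutaryl-coenzyme A reductase (Rattus norvegicus) (a higher number here means a weaker inhibitor, a lower number a stronger inhibitor), compound 1 gives 15 nM, the lowest of the two numbers. Compound 2 gives 22 nM, and a 1.5-fold higher number from compound 1 to compound 2 (0.17 log units; within the scatter), so the two compounds stand within the scatter of each other and no order between them can be read.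

Compound 3, `CC(C)c1c(C(=O)N(C)Cc2cccc(Cl)c2)nn(-c2ccc(F)cc2)c1OC[C@@H](O)C[C@@H](O)CC(=O)O`, has not yet been measured in this assay. It differs from compound 1 in (3-chlorobenzyl)(methyl)amino in place of (4-methylbenzyl)amino on a carbonyl carbon. Within the data shown here, the only measured step that bears on this change is a 1.5-fold higher number from compound 1 to compound 2 (0.17 log units; within the scatter), which swaps one substituent on the benzyl ring for another and stays within the scatter; that speaks for substitution on that ring being tolerated. Among the measured compounds shown here, no measured pair covers the second part of the change, the loss of the hydrogen-bond donor on the amide nitrogen, so that part remains uncovered by the data. A modest rise in the number is therefore expected, mostly as a margin for the uncovered part. The expected step is a 2.0-fold higher number from compound 1 to compound 3 (0.30 log units; within the scatter). For compound 3 the expected value in this assay is 30 nM, with a range from 10 nM to 100 nM.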

Compound 3, half-maximal inhibitory concentration: 8.3 nM
For compound 3 the middle estimate is 3.6-fold (0.56 log units) above the measured one; measured number outside the range, below it.
By their numbers in this assay, from the lowest: compounds 3, 1 and 2 (each within the scatter of the next, the first and the last beyond it).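

In this assay, the step of a 1.8-fold lower number from compound 1 to compound 3 (0.26 log units; within the scatter) shows that the amide hydrogen on this carbonyl carbon can be lost, with (3-chlorobenzyl)(methyl)amino in place of (4-methylbenzyl)amino, without any change that can be read; the earlier pair covered only a swap of benzyl ring substituents with the amide hydrogen kept. Among these compounds, the step of a 2.7-fold lower number from compound 2 to compound 3 (0.42 log units; beyond the scatter) is the first in this set beyond the scatter, and it is modest, so replacing (2-methoxybenzyl)amino at this place does move the number, while compound 1 stays within the scatter of both compound 2 and compound 3. No measurement at hand accounts for these numbers.

The step from compound 1 to compound 3 changes the ring substituent and the amide nitrogen together, so the share of the chlorine and the share of the added methyl stay unseparated, and a matched pair differing only in the amide hydrogen would be needed to part them. Also open, from the compounds shown here alone, is how this place responds to an ethyl or a longer chain on the amide nitrogen, or to an amine on the benzyl ring.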